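The compounds below may be only part of what the source reports. "The series", "measured", "known", "first", "only" and "open" are said of these compounds alone.

Of the compounds shown here, two built on the same core have been tested in a functional assay on MCF7 cells (Homo sapiens) for cytotoxicity, read by MTT assay, with a stated time of 72 h; a lower number here means a stronger inhibitor, a higher number a weaker inhibitor. Compound 1 `N#Cc1cnn(-c2ccc(S(N)(=O)=O)cc2)c1N` reaches only the limit of the test, > 100000 nM, which is a limit and not a measured number. Among the compounds with values here, compound 2 `NS(=O)(=O)c1ccc(-n2ncc3c(=O)[nH]c(-c4ccc(F)cc4)nc32)cc1` gives 38000 nM in this assay, the only real number obtained so far. Compound 1 sits at the limit of > 100000 nM in this assay, at which 1 of the 2 values shown sits. Compound 3 `NS(=O)(=O)c1ccc(-n2ncc3c(=O)[nH]c(-c4ccc(Br)cc4)nc32)cc1` has not yet been tested; it differs from compound 2 in one place, (bromo in place of fluoro on an aromatic carbon), that is, bromo in place of fluoro on an aromatic carbon. Within the data shown here, no pair of measured compounds shows how such a swap shifts the read-out, so there is no measured step to lean on. In its absence, the step from compound 2 to compound 3 is estimated at a 1.5-fold lower number from compound 2 to compound 3 (0.18 log units; within the scatter), a shift expected to stay within the ordinary scatter. Compound 3 is therefore expected to give about 25000 nM in this assay, with a plausible range from 8000 nM to 80000 nM.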

Compound 3, half-maximal inhibitory concentration: 14500 nM
Compound 3: the middle estimate sits 1.7-fold (0.24 log units) above what was measured, within the range that was stated.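

Replacing 4-fluorophenyl with 4-bromophenyl gives a 2.6-fold lower number from compound 2 to compound 3 (0.42 log units; beyond the scatter) in this assay, so this position, para to a large group, is not indifferent to what it carries. The swap exchanges one heavy atom for another, and no hydrogen-bond donors or acceptors enter or leave, yet the shift still lies beyond the scatter, though only modestly. Compound 1 offers no further number for comparison, only a limit: the limit of > 100000 nM in this assay, at which 1 of the 3 values shown sits.

A single pair cannot show whether the read-out would keep moving in the same direction with other groups at this position, such as chloro, methyl or an amine. Nor does it reveal which difference between bromo and fluoro lies behind the step, so its cause remains unknown.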